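A few compounds are considered here, and "the series" means these few. Any claim that something is new, unique, unknown or untested is made for them only; others in the source may bear on it.

Of the compounds shown here, three sharing one core have been measured in a physicochemical assay for lipophilicity, read by HPLC, at pH 7.4; a lower number here means a more polar compound, a higher number a more lipophilic compound. Compound 1 `CS(=O)(=O)c1ccc(-c2cnc(N)c(-c3ccc(C(F)(F)F)cc3)c2)cc1`, which carries trifluoromethyl, gives 3.4. Compound 2 `CS(=O)(=O)c1ccc(-c2cnc(N)c(-c3ccc(S(C)(=O)=O)cc3)c2)cc1`, with methylsulfonyl in that place, gives 2. Compound 3 `CNC(=O)c1ccc(-c2cc(-c3ccc(S(C)(=O)=O)cc3)cnc2N)cc1`, with methylcarbamoyl there, gives 1.7, which puts it well under compound 1 and within the scatter of compound 2.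

Exchanging trifluoromethyl produced large steps: a number 1.40 log units lower from compound 1 to compound 2 (beyond the scatter) with methylsulfonyl and a number 1.70 log units lower from compound 1 to compound 3 (beyond the scatter) with methylcarbamoyl. Exchanging methylsulfonyl for methylcarbamoyl produced a number 0.30 log units lower from compound 2 to compound 3 (within the scatter).

Compound 4 `CS(=O)(=O)c1ccc(-c2cnc(N)c(-c3ccc(C(N)=O)cc3)c2)cc1` alters only the methylcarbamoyl group of compound 3: hydrogen in place of methyl on an amide-type nitrogen. This is hydrogen in place of methyl on an amide-type nitrogen, so methylcarbamoyl becomes carbamoyl. Going by the values given here, no measured step makes this exact change, so the evidence is indirect. The two large steps each replaced trifluoromethyl outright, which is a much bigger edit than this one. The closer guide is therefore the exchange that stayed within the scatter.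

A small downward step is expected, possibly no larger than the scatter. The expected step is a number 0.30 log units lower from compound 3 to compound 4 (within the scatter). For compound 4 the estimated value in this assay is 1.4, with an expected range from 1 to 1.8.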

Compound 4, distribution coefficient: 1.5
Compound 4: the middle estimate sits 0.10 log units below what was measured, and the stated range covers the measured number.
By their numbers in this assay, from the lowest: compounds 4, 3 and 2 (each within the scatter of the next, the first and the last beyond it); then compound 1.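

Hydrogen in place of methyl on the amide-type nitrogen is the first change measured at the nitrogen itself, and in this assay it leaves a difference that cannot be told from the scatter (a number 0.20 log units lower from compound 3 to compound 4 (within the scatter)), so for this pair the methyl makes no readable difference. Carbamoyl, on the other hand, does stand apart from methylsulfonyl at this place on the shared core (a number 0.50 log units lower from compound 2 to compound 4 (beyond the scatter)), whereas methylcarbamoyl did not (a number 0.30 log units lower from compound 2 to compound 3 (within the scatter)), and its exchange for trifluoromethyl gives the largest step yet seen here (a number 1.90 log units lower from compound 1 to compound 4 (beyond the scatter)). No measurement at hand gives a reason for any of these differences.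

As far as these compounds go, only hydrogen and methyl have been compared on this nitrogen, so it remains open whether an ethyl group or a longer chain there would also stay within the scatter of compound 3. From the compounds shown here alone, it is equally open where a carboxylic acid or an amine would fall if either took the place of the whole carbamoyl group, and whether the same exchanges would give similar steps on a different core.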